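The source may report more compounds than this note shows. Statements on the series, on what has been measured and on what is new or still open speak of the compounds shown alone.

Compound 1 `COc1cc(C(=O)/C=C/c2ccc(OCCCC(=O)NCCCNCCCCN)cc2)cc(OC)c1OC` and compound 3 `COc1cc(C(=O)/C=C/c2ccc(OCCCC(=O)NCCCCNCCCN)cc2)cc(OC)c1OC` share one core, while compound 2 `COc1ccc(/C=C/C(=O)c2cc(OC)c(OC)c(OC)c2)cc1OCCCC(=O)NCCCNCCCCN` and compound 4 `COc1ccc(/C=C/C(=O)c2cc(OC)c(OC)c(OC)c2)cc1OCCCC(=O)NCCCCNCCCN` share another; the difference between the two cores is not broken down here. In a functional assay on HT-29 cells (Homo sapiens) for antiproliferative activity, read by MTT assay, with a stated time of 48 h (a lower number here means a stronger inhibitor, a higher number a weaker inhibitor), compound 1 gives > 100000 nM, which is a limit of the assay rather than a number. In this assay compound 3 gives > 100000 nM, again a limit. The change between them, (((3-aminopropyl)amino)methyl in place of (4-aminobutyl)amino on a saturated chain carbon, three bonds along the chain from an amide-type nitrogen), is therefore a step that the two limits leave unreadable from compound 1 to compound 3, because both readings sit at the limit of > 100000 nM in this assay, at which 3 of the 3 values shown sit. In this assay compound 2 gives > 100000 nM, also a limit. Compound 4 carries the same change, (((3-aminopropyl)amino)methyl in place of (4-aminobutyl)amino on a saturated chain carbon, three bonds along the chain from an amide-type nitrogen). Compound 4 is expected to move by a step that the limit leaves unreadable from compound 2 to compound 4, because every measured compound sits at the limit of > 100000 nM in this assay, at which 3 of the 3 values shown sit. Compound 4 is estimated at 150000 nM, expected between 60000 nM and 500000 nM, and most likely reported only as a limit.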

Compound 4, half-maximal inhibitory concentration: > 100000 nM
Compound 4: a limit, no number (the forecaster's own chance of this, stated with the estimate: 90%); the middle value is on the limit's open side.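

Compound 2 and compound 4 both give only a limit rather than a number, so no step can be read between them: the limit of > 100000 nM in this assay, at which 4 of the 4 values shown sit.

The compounds shown leave open how strongly any of them acts on these cells, and whether this chain change alters that at all.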